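Charged ring variant of compound 2: expected potency

The compounds below may be only part of what the source reports. "The series", "measured", "known", "first", "only" and "open" are said of these compounds alone.

Within the data shown here, compound 2 `COc1cc(C(=O)/C=C/c2ccncc2)cc(OC)c1OC` is the only member with a definite number in a functional assay with Rattus norvegicus as the target (on this read-out higher numbers stand for weaker inhibition and lower numbers for stronger inhibition), where compound 2 gives 7000 nM. Compound 1 `COc1cc(C(=O)/C(C)=C/c2ccncc2)cc(OC)c1OC` returns only a limit of the assay, > 100000 nM. Compound 3 `COc1cc(C(O)/C=C/c2ccncc2)cc(OC)c1OC` likewise returns only a limit, > 100000 nM. The picture is shaped by the limit of > 100000 nM in this assay, at which 2 of the 3 values shown sit, leaving compound 2 as the sole definite potency in the set. Compound 4 `COc1cc(C(=O)/C=C/c2cc[n+](C)cc2)cc(OC)c1OC` differs from compound 2 by a group of 7 heavy atoms (6 carbon, 1 nitrogen; one six-membered aromatic ring with 1 hetero atom) in place of a group of 6 heavy atoms (5 carbon, 1 nitrogen; one six-membered aromatic ring with 1 hetero atom), on a double-bonded chain carbon bound to a double-bonded chain carbon. Among the measured compounds shown here, no step between measured compounds is available for comparison, so the size of this change rests on expectation alone. A weakening beyond the usual scatter is expected, a 4.3-fold higher number from compound 2 to compound 4 (0.63 log units; beyond the scatter). Compound 4 is therefore estimated at about 30000 nM in this assay, within a range from 7000 nM to 100000 nM, with a real chance that only a limit is reported.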

Compound 4, half-maximal inhibitory concentration: > 50000 nM
Compound 4: a limit, no number (the forecaster's own chance of this, stated with the estimate: 40%); at least 1.6-fold (0.22 log units) between middle value and limit.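

In this assay, the series gains its first reading of a change at the pyridin-4-yl group, and the replacement with net charge +1 is not tolerated without loss: an at least 7.1-fold higher number from compound 2 to compound 4 (0.85 log units; beyond the scatter). Compound 4 gives only a limit of the assay, so the true size of this loss stays unknown because no definite number exists for it: the limit of > 50000 nM in this assay, at which 1 of the 4 values shown sits.

The compounds shown do not separate the net charge from the added carbon as the source of the loss. Also open, as far as these compounds go, is what a 4-aminophenyl group or a carboxylic acid would give on the same double-bonded chain carbon.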